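A few compounds are considered here, and "the series" means these few. Any claim that something is new, unique, unknown or untested is made for them only; others in the source may bear on it.

Compound 1 `O=C1/C(=C/c2cccnc2)CN(S(=O)(=O)c2ccc(Cl)cc2)C/C1=C\c1ccccc1F` and compound 2 `O=C1/C(=C/c2cccnc2)CN(S(=O)(=O)c2ccc(Br)cc2)C/C1=C\c1ccccc1F` share one core; compound 3 `O=C1/C(=C/c2ccncc2)CN(S(=O)(=O)c2ccc(Cl)cc2)C/C1=C\c1ccccc1C(F)(F)F` and compound 4 `O=C1/C(=C/c2ccncc2)CN(S(=O)(=O)c2ccc(Br)cc2)C/C1=C\c1ccccc1C(F)(F)F` share another. In a functional assay on SMMC-7721 cells (Homo sapiens) for cytotoxicity, read by MTT assay, with a stated time of 24 h (on this read-out lower numbers stand for stronger inhibition and higher numbers for weaker inhibition), compound 1 gives 16100 nM, and in this assay compound 2 gives 9100 nM. The change between them is bromo in place of chloro on an aromatic carbon; it produced a 1.8-fold lower number from compound 1 to compound 2 (0.25 log units; within the scatter). In this assay compound 3 gives 5510 nM. The difference between the core of compound 1 and the core of compound 3 is not broken down here, so those two values simply stand side by side. Compound 4 carries the same change relative to compound 3, (bromo in place of chloro on an aromatic carbon), and the place is described in the same words for both pairs, so it is the same change, not merely the same kind. Because the step of a 1.8-fold lower number from compound 1 to compound 2 (0.25 log units; within the scatter) stayed within the scatter, a step of similar size is expected for compound 4: a 1.6-fold lower number from compound 3 to compound 4 (0.20 log units; within the scatter). On that basis compound 4 is estimated at 3500 nM in this assay, with a likely range from 1500 nM to 8000 nM.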

Compound 4, half-maximal inhibitory concentration: 10500 nM
Estimate against measurement, compound 4: 3.0-fold (0.48 log units) below; the whole stated range lies below it.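

In this assay the new step is a 1.9-fold higher number from compound 3 to compound 4 (0.28 log units; within the scatter), and set beside the earlier step it does not carry over unchanged: the same change on two cores in this assay, a 1.8-fold lower number (0.25 log units; within the scatter) from compound 1 to compound 2 and a 1.9-fold higher number (0.28 log units; within the scatter) from compound 3 to compound 4, 3.4-fold (0.53 log units) apart, beyond the scatter of two such steps. On these two pairs, the step for bromo in place of chloro read on one core is therefore no safe figure for the other core, and a transfer between these cores should not be assumed. This does not show that bromo is better or worse than chloro on either core, since each step taken alone stays within the scatter, and it rests on a single pair per core, with nothing here to say which difference between the cores goes with the gap.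

Open, as far as these compounds go, is how a methoxy group, a nitrile or an amine in place of the halogen on that aromatic carbon would read in this assay. Also open, from the compounds shown here alone, is whether the two cores would part in the same way with those groups, or whether the gap is confined to the chloro and bromo pairs.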